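Compound 2 Swaps Amino for 2-Aminobutoxy

The source may hold more compounds than are shown below. What is called first, only, known or untested is meant among the compounds shown, and "the series" means these compounds.

Measured in a functional assay on MCF7 cells (Homo sapiens) for inhibition, read by fluorescence, with a stated time of 72 h; on this read-out lower numbers stand for stronger inhibition and higher numbers for weaker inhibition:
- Compound 1 `Cn1cnc2c(NC(=N)N)nc(N)nc21`: > 100000 nM, a limit
- Compound 2 `CC(C)n1cnc2c(NC(=N)N)nc(N)nc21`: 97200 nM
- Compound 3 `N=C(N)Nc1nc(N)nc2c1ncn2CCO`: > 100000 nM, a limit

Among the compounds with values here, compound 2 gives the only true number of the three. The rest of the picture is the limit of > 100000 nM in this assay, at which 2 of the 3 values shown sit.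

Compound 4 `CC[C@H](N)COc1nc(NC(=N)N)c2ncn(C(C)C)c2n1` keeps the isopropyl group of compound 2 and changes another site: 2-aminobutoxy in place of amino on an aromatic carbon.

The measured steps all concern the group on the aromatic nitrogen. They are an at least 1.0-fold lower number from compound 1 to compound 2 (0.01 log units; that floor lies within the scatter), an at least 1.0-fold higher number from compound 2 to compound 3 (0.01 log units; that floor lies within the scatter) and a step that the two limits leave unreadable from compound 1 to compound 3. The first two are floors within the scatter, and the third cannot be read. Within the data shown here, none touches the site that changes in compound 4, so they set no size for this step.

Compound 2 at 97200 nM has little room left before this assay stops giving numbers, so any readable change is expected to be towards a lower number, and only a modest one. The expected size is a 2.8-fold lower number from compound 2 to compound 4 (0.44 log units; beyond the scatter). Compound 4 is estimated at 35000 nM, with an expected range of 8000 nM to 100000 nM.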

Compound 4, half-maximal inhibitory concentration: 16300 nM
Compound 4: middle estimate off by 2.1-fold (0.33 log units), on the high side; the measured number falls inside the stated range.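

In this assay, this position on an aromatic carbon between two ring nitrogen atoms responds to change: 2-aminobutoxy in place of amino gives a 6.0-fold lower number from compound 2 to compound 4 (0.78 log units; beyond the scatter). The entering group brings several features at once, namely a longer chain, an oxygen and one defined stereocentre, and this single step cannot separate them. It is still the first clearly readable step in the series, because the earlier comparisons, all at the group on the aromatic nitrogen, were held back by the assay's limit: the limit of > 100000 nM in this assay, at which 2 of the 4 values shown sit.

It remains open which part of 2-aminobutoxy accounts for the step, and a plain butoxy chain without the amine, or a longer hexyloxy chain, would bear on that. Also open, as far as these compounds go, is whether the same swap would give a similar step with methyl or 2-hydroxyethyl on the aromatic nitrogen.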